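The source may report more compounds than this note shows. Statements on the series, on what has been measured and on what is new or still open speak of the compounds shown alone.

Compound 1 `Cc1cc(C(=O)O)ccc1OCCCCOc1ccc(C(=O)CC(C)C)c(O)c1C` gives 1850 nM in an assay on HEK293 cells for positive allosteric modulation of metabotropic glutamate receptor 3 (Rattus norvegicus), read by thallium flux, with a stated time of 2.5 min; on this read-out lower numbers stand for an effect already at smaller amounts and higher numbers for an effect only at larger amounts of compound.
Compound 3 `CCCC(=O)c1ccc(OCCCCOc2ccc(C(=O)O)cc2C)c(C)c1O` reaches only a limit of the assay, > 10000 nM.
Compound 2 `COC(=O)c1ccc(OCCCCOc2ccc(C(=O)CC3CCCC3)c(C)c2C)cc1` shows "not determined" (no result reported).

Compound 1 therefore holds the only plain number among these three. For compound 3 the value is a limit, not a number, and it sits at the limit of > 10000 nM in this assay, at which 1 of the 3 values shown sits. For the measured compounds named here, the one measured step, an at least 5.4-fold higher number from compound 1 to compound 3 (0.73 log units; beyond the scatter), alters the ketone side chain, far from the carboxy-bearing ring.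

Compound 4 `Cc1c(OCCCCOc2ccc(C(=O)O)cc2Cl)ccc(C(=O)CC(C)C)c1O` differs from compound 1 by chloro in place of methyl on an aromatic carbon. Going by the values given here, no measured step touches that ring, so nothing here bears directly on this change, and the step from the side chain is not a guide to it. Without such evidence, a change not beyond the scatter is expected, a 1.4-fold higher number from compound 1 to compound 4 (0.13 log units; within the scatter). Compound 4 is thus estimated at 2500 nM, with a range from 900 nM to 8000 nM.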

Compound 4, half-maximal effective concentration: 1140 nM
Estimate against measurement, compound 4: 2.2-fold (0.34 log units) above, within the range that was stated.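

For the compounds shown here, on the carboxy-bearing ring, at the place ortho to a large group, chloro in place of methyl gives a 1.6-fold lower number from compound 1 to compound 4 (0.21 log units; within the scatter) in this assay, the first measured step on this ring. Unlike the side-chain step, it stays within the scatter, so these two groups cannot be told apart at this position. Nothing measured here gives a reason for this result.

Going by these compounds, whether fluoro, methoxy or a nitrile at this position would behave the same stays open. So does whether chloro would give a similar result alongside a different ketone side chain.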